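Propyl for isopropyl on the amide across two cores

The source may report more compounds than this note shows. Statements on the series, on what has been measured and on what is new or still open speak of the compounds shown alone.

Compound 1 `CCC1C(=O)N(C)c2cnc(-n3ccc4cc(C(=O)NC(C)C)ccc43)nc2N1c1ccn(C)n1` and compound 2 `CCCNC(=O)c1ccc2c(ccn2-c2ncc3c(n2)N(c2ccn(C)n2)C(CC)C(=O)N3C)c1` share one core. In a functional assay on MCF7 cells (Homo sapiens) for antiproliferative activity, read by CCK-8 assay, with a stated time of 72 h (a lower number here means a stronger inhibitor of growth, a higher number a weaker inhibitor of growth), compound 1 gives 8420 nM and compound 2 gives 6420 nM. The change between them is propyl in place of isopropyl on an amide-type nitrogen and the step it made is a 1.3-fold lower number from compound 1 to compound 2 (0.12 log units; within the scatter). Compound 3 `CC[C@@H]1C(=O)N(C)c2cnc(-n3ccc4cc(C(=O)NC(C)C)ccc43)nc2N1C1CCCC1` carries a different core; the difference between the two cores is not broken down here. In this assay compound 3 gives 1670 nM, the lowest of the three numbers and beyond the scatter from both others. Compound 4 `CCCNC(=O)c1ccc2c(ccn2-c2ncc3c(n2)N(C2CCCC2)[C@H](CC)C(=O)N3C)c1` differs from compound 3 by propyl in place of isopropyl on an amide-type nitrogen, the same change at the same place, on an amide-type nitrogen whose other neighbours are a carbonyl carbon. The expected step is a 1.3-fold lower number from compound 3 to compound 4 (0.11 log units; within the scatter), resting on the earlier step being a 1.3-fold lower number from compound 1 to compound 2 (0.12 log units; within the scatter). In this assay compound 4 is estimated at 1300 nM, expected between 600 nM and 3200 nM.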

Compound 4, concentration for 50% growth inhibition: 592 nM
The estimate for compound 4 lay 2.2-fold (0.34 log units) above the measured number; measured number outside the range, below it.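

In this assay propyl in place of isopropyl on the amide nitrogen gives a 2.8-fold lower number from compound 3 to compound 4 (0.45 log units; beyond the scatter) on the core of compound 3. This shows that the change carries from one core to the other with no step size that can be told apart, although two cores cannot show that the step holds on further cores in the series. The two steps compare as follows: the same change on two cores in this assay, a 1.3-fold lower number (0.12 log units; within the scatter) from compound 1 to compound 2 and a 2.8-fold lower number (0.45 log units; beyond the scatter) from compound 3 to compound 4, 2.2-fold (0.33 log units) apart, within the scatter of two such steps.

Still open, going by these compounds, is how a butyl chain or a cyclopropylmethyl group on the same amide nitrogen would read in this assay on either core. Also open, on these data alone, is whether a carboxylic acid at the end of the propyl chain would keep the step.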